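The compounds below may be only part of what the source reports. "The series", "measured", "known", "first", "only" and "open" are said of these compounds alone.

- compound 1 (`COc1cccc(-c2oc3ccc(N)cc3c(=O)c2OC)c1`) 251000 nM
- compound 2 (`COc1c(-c2cccc(F)c2)oc2ccc(N)cc2c1=O`) 113000 nM

In an ADME assay on MT4 cells (Homo sapiens) for cytotoxicity, read by MTT assay, with a stated time of 4 days (a higher number here means that more compound is tolerated, a lower number that less compound is tolerated), compound 2 has the lower of the two numbers at 113000 nM and so is tolerated at a lower concentration than compound 1. Compound 3 (`COc1c(-c2cccc(C(F)(F)F)c2)oc2ccc(N)cc2c1=O`) carries trifluoromethyl in place of fluoro on an aromatic carbon. Among the measured compounds shown here, only one measured step bears on this change: a 2.2-fold lower number from compound 1 to compound 2 (0.35 log units; beyond the scatter) (modest), with fluoro in place of methoxy on an aromatic carbon. One step is thin guidance, but a similarly modest move to a lower number is expected (a 1.6-fold lower number from compound 2 to compound 3 (0.21 log units; within the scatter)). For compound 3 the estimated value is 70000 nM (expected range 30000 nM to 160000 nM).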

Compound 3, half-maximal cytotoxic concentration: 73100 nM
Beside the measured number, compound 3's estimate is 1.0-fold (0.02 log units) below it; the measured number falls inside the stated range.
By their numbers in this assay, from the lowest: compounds 3 and 2 (each within the scatter of the next); then compound 1.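

In this assay, the change to trifluoromethyl gives a 1.5-fold lower number from compound 2 to compound 3 (0.19 log units; within the scatter) and so cannot be told apart from fluoro at this position, on an aromatic carbon meta to a large group. Measured against methoxy, the same change gives a 3.4-fold lower number from compound 1 to compound 3 (0.54 log units; beyond the scatter) and so is a real difference, which means that among these three compounds, methoxy stands apart from both fluorine-bearing groups. Nothing measured here explains this result. Going by these compounds, how an amine or a carboxylic acid at this position would compare remains open. So does whether a longer chain would follow the fluorine-bearing groups or methoxy.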